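Carbonyl aryl swap on the shared core: compound 1 to compound 4

This account rests on a few compounds, and the source may have more. Where it says the series, first, only, none or still open, it means among the compounds named here.

Measured so far:
- compound 1 `Cc1cccc(Cn2c(CN3CCN(C(=O)c4cccnc4)CC3)nc3ccccc32)c1`: 24.5%
- compound 2 `O=C(C1CC1)N1CCN(Cc2nc3ccccc3n2Cc2ccccc2F)CC1`: 40.7%
- compound 3 `COc1cccc(Cn2c(CN3CCN(C(=O)C4CC4)CC3)nc3ccccc32)c1`: 44.4%

In an assay on isolated protein for inhibition of aldehyde dehydrogenase 1A1 (Homo sapiens), read by spectrophotometry, tested at 10 uM (a higher number here means more inhibition at the concentration tested (going by the name of the read-out), a lower number less inhibition), compound 1 gives the lowest of the three numbers; the gap to compound 2 and to compound 3 is beyond the scatter in each case. Compound 4 `COc1ccc(C(=O)N2CCN(Cc3nc4ccccc4n3Cc3cccc(C)c3)CC2)cc1` differs from compound 1 in one place: 4-methoxyphenyl in place of pyridin-3-yl on a carbonyl carbon. Going by the values given here, the only measured single-point step, a number 3.7 percentage points higher from compound 2 to compound 3 (within the scatter), concerns the group on the saturated chain carbon bound to the aromatic nitrogen, not the carbonyl carbon, so no step bears directly on this change. Compounds 2 and 3 carry a different carbonyl substituent and a different benzyl group, so their higher numbers offer only an indirect hint. Compound 4 is therefore expected to show a step of about a number 5.5 percentage points higher from compound 1 to compound 4 (within the scatter), around the scatter rather than clearly beyond it. The estimate for compound 4 is 30%, within 14% to 48%.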

Compound 4, a percentage reported as inhibition, at one concentration (the size of the read-out at that concentration, not a potency): 55.5%
Compound 4: middle estimate off by 25.5 percentage points, on the low side, outside the stated range (above it).
By their numbers in this assay, from the lowest: compound 1; then compounds 2 and 3 (each within the scatter of the next); then compound 4.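

In this assay the group on the carbonyl carbon proves to be a sensitive position: 4-methoxyphenyl in place of pyridin-3-yl gives a step of a number 31 percentage points higher from compound 1 to compound 4 (beyond the scatter). Going by these compounds alone, the one earlier single-place step, at the group on the saturated chain carbon, stayed within the scatter (a number 3.7 percentage points higher from compound 2 to compound 3 (within the scatter)). No measurement at hand accounts for the size of the new step.

Open, from the compounds shown here alone, is whether the step follows the methoxy group or the loss of the ring nitrogen; plain phenyl on the carbonyl carbon would separate the two. Also open, going by these compounds, is how 4-methoxyphenyl compares with cyclopropyl there with the benzyl group held constant.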